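Working notes: from compound 3 to compound 4

The source may hold more compounds than are shown below. What is called first, only, known or untested is meant among the compounds shown, and "the series" means these compounds.

Three compounds have numbers in a functional assay on WM 266-4 cells (Homo sapiens) for inhibition, read by MTT assay, with a stated time of 24 h; on this read-out lower numbers stand for stronger inhibition of growth and higher numbers for weaker inhibition of growth. Compound 1 `COc1ccc(C2CC(c3ccc(Br)cc3)=NN2C(=O)C2COc3ccccc3O2)cc1` gives 9010 nM. Compound 2 `O=C(C1COc2ccccc2O1)N1N=C(c2ccccc2)CC1c1cccc(F)c1` gives 1450 nM. Compound 3 `COc1ccc(C2CC(c3ccc(Br)cc3)=NN2C(=O)c2ccc3c(c2)OCCO3)cc1` gives 5680 nM. Within the data shown here, compound 3 stands second highest of the three: its nearest neighbour is compound 1, at a gap within the scatter, and the only single-place step measured so far, a 1.6-fold lower number from compound 1 to compound 3 (0.20 log units; within the scatter), puts 2,3-dihydro-1,4-benzodioxin-6-yl in place of 2,3-dihydro-1,4-benzodioxin-2-yl on the carbonyl carbon without leaving the scatter. Among the measured compounds shown here, compound 2 sits beyond the scatter from compound 3, but it differs from compound 3 in several places at once, so the two values show only that the numbers differ.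

Compound 4 `COc1ccc(C2CC(c3ccccc3)=NN2C(=O)c2ccc3c(c2)OCCO3)cc1` is not yet measured. It differs from compound 3 by hydrogen in place of bromo on an aromatic carbon. For the measured compounds named here, no measured step bears on this change: the one step available, a 1.6-fold lower number from compound 1 to compound 3 (0.20 log units; within the scatter), concerns the acyl side and says nothing about the bromo. Compound 2 carries phenyl rather than 4-bromophenyl and a lower number, but with other changes alongside, so it is no guide on its own. The expectation for compound 4 in this assay is therefore no step beyond the scatter, a 1.1-fold lower number from compound 3 to compound 4 (0.06 log units; within the scatter), with wide uncertainty. The estimated value for compound 4 is 5000 nM, within 2000 nM to 12000 nM.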

Compound 4, concentration for 50% growth inhibition: 8370 nM
Estimate against measurement, compound 4: 1.7-fold (0.22 log units) below, and the stated range covers the measured number.
By their numbers in this assay, from the lowest: compound 2; then compounds 3, 4 and 1 (each within the scatter of the next).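

In this assay, the change on this aromatic carbon, para to a large group, now has a step of its own: a 1.5-fold higher number from compound 3 to compound 4 (0.17 log units; within the scatter). The earlier compounds shown here gave a single-place step only on the acyl side, whereas this one shows that, with the 2,3-dihydro-1,4-benzodioxin-6-yl group on the carbonyl carbon, going from 4-bromophenyl to phenyl leaves the number within the scatter, so the bromo shows no readable contribution in this pair. No measured evidence bears on this result, and the step stands as a bare observation on one pair of compounds.

What the compounds shown leave open is whether the same change would also stay within the scatter with the 2,3-dihydro-1,4-benzodioxin-2-yl group on the carbonyl carbon, or with a different group on the other aromatic ring of the shared core. Also open, from the compounds shown here alone, is whether this aromatic carbon tolerates groups of a different kind, such as an amine or a carboxylic acid, since only bromo and hydrogen have been compared there.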